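The source may report more compounds than this note shows. Statements on the series, on what has been measured and on what is new or still open speak of the compounds shown alone.

Values in a functional assay on MCF7 cells (Homo sapiens) for inhibition; on this read-out lower numbers stand for stronger inhibition and higher numbers for weaker inhibition:
- Compound 1 `CCCCCCCC[C@@]1(C)SC(O)=C(C)C1=O`: 16.5 ug/mL
- Compound 2 `CCCCCCCC[C@@]1(C)SC(=O)C=C1OCC(=O)OCC`: 10.8 ug/mL
- Compound 3 `C=CCNC(=O)COC1=CC(=O)S[C@]1(C)CCCCCCCC`: > 50 ug/mL

Compound 3 gives > 50 ug/mL, which is a limit of the assay and not a number. Going by the values given here, it is the only compound at the limit of > 50 ug/mL in this assay, at which 1 of the 3 values shown sits, so its true position in this assay remains unknown.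

Compound 4 `C=CCOC(=O)OC1=CC(=O)S[C@]1(C)CCCCCCCC` is the next compound to be tested. It differs from compound 3 as follows: allyloxycarbonyl in place of (allylcarbamoyl)methyl on an oxygen on an unsaturated carbon. In short, allyloxycarbonyl stands in place of (allylcarbamoyl)methyl on an oxygen on an unsaturated carbon.

Among the compounds with values here, one measured step bears on this change: an at least 4.6-fold higher number from compound 2 to compound 3 (0.66 log units; beyond the scatter). It brought in the allylamino group on a carbonyl carbon, and compound 4 gives up that group while keeping an allyl end. The step is only an indirect guide, since the atoms joining the carbonyl to the shared core change as well. Even so, a move back toward the numbers of compound 1 and compound 2 is expected, with a modest step to a lower number in this assay. The estimated step is an at least 2.6-fold lower number from compound 3 to compound 4 (0.42 log units; beyond the scatter), and it remains uncertain because its starting point is a limit. For compound 4 the expected value is 19 ug/mL, within an estimated range of 8 ug/mL to 45 ug/mL.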

Compound 4, half-maximal inhibitory concentration: 14.2 ug/mL
For compound 4 the middle estimate is 1.3-fold (0.13 log units) above the measured one; low and high end bracket the measured number.
By their numbers in this assay, from the lowest: compounds 2, 4 and 1 (each within the scatter of the next). At a limit, above all of these: compound 3.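

In this assay, allyloxycarbonyl on this oxygen gives an at least 3.5-fold lower number from compound 3 to compound 4 (0.54 log units; beyond the scatter), so an allyl end does not by itself go with the weak result of compound 3. Compound 2 and compound 4 carry different groups at this place, yet the change between them gives a 1.3-fold higher number from compound 2 to compound 4 (0.12 log units; within the scatter), so the assay does not separate allyloxycarbonyl from (ethoxycarbonyl)methyl. Of the three groups compared on this oxygen, only the (allylcarbamoyl)methyl of compound 3, the one group with a nitrogen and a hydrogen-bond donor, stands apart, and the size of that gap is known only as a bound, as compound 3 sits at a limit of the assay and not at a number: the limit of > 50 ug/mL in this assay, at which 1 of the 4 values shown sits.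

The compounds shown leave open whether the nitrogen itself accounts for the gap or the allylamino group as a whole does, which a simple ethylamide or a free carboxylic acid on the same methyl-linked carbonyl would help to separate. They also leave open how far the values depend on the long chain of the shared core, for which a shorter or longer chain would be the comparison.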